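This account rests on a few compounds, and the source may have more. Where it says the series, first, only, none or still open, it means among the compounds named here.

Compound 1, `Cc1ccccc1-n1cc(-c2ccc(NS(=O)(=O)c3c[nH]c(=O)[nH]c3=O)cc2)nn1`, in a functional assay on SGC-7901 cells (Homo sapiens) for antiproliferative activity, read by MTT assay, with a stated time of 24 h; a higher number here means a weaker inhibitor, a lower number a stronger inhibitor: compound 1 gives 13600 nM.
Compound 2, `Cc1ccc(-n2cc(-c3ccc(NS(=O)(=O)c4c[nH]c(=O)[nH]c4=O)cc3)nn2)cc1`: in this assay compound 2 gives 8350 nM.
Compound 3, `O=c1[nH]cc(S(=O)(=O)Nc2ccc(-c3cn(-c4ccccc4Cl)nn3)cc2)c(=O)[nH]1`: in this assay compound 3 gives 2680 nM.

Among these three, compound 3 carries the lowest number. Its nearest neighbour is compound 2, separated by a 3.1-fold lower number from compound 2 to compound 3 (0.49 log units; beyond the scatter), and its furthest is compound 1, separated by a 5.1-fold lower number from compound 1 to compound 3 (0.71 log units; beyond the scatter); both steps lie beyond the scatter, so compound 3 is the strongest inhibitor of the measured set.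

Compound 4, `O=c1[nH]cc(S(=O)(=O)Nc2ccc(-c3cn(-c4cccc(Cl)c4)nn3)cc2)c(=O)[nH]1`, has not yet been measured. It differs from compound 3 by 3-chlorophenyl in place of 2-chlorophenyl on an aromatic nitrogen. Among the compounds with values here, only one measured step moves a group around the phenyl ring that sits on the triazole nitrogen: a 1.6-fold lower number from compound 1 to compound 2 (0.21 log units; within the scatter), which stayed within the scatter. The step of a 5.1-fold lower number from compound 1 to compound 3 (0.71 log units; beyond the scatter) swapped methyl for chloro on the same carbon and therefore says nothing about shifting the chloro itself. On this basis, compound 4 is expected to show no step beyond the scatter, roughly a 1.2-fold higher number from compound 3 to compound 4 (0.08 log units; within the scatter). Compound 4 is estimated at 3200 nM in this assay, with a likely range from 1200 nM to 8500 nM.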

Compound 4, half-maximal inhibitory concentration: 2460 nM
For compound 4 the middle estimate is 1.3-fold (0.11 log units) above the measured one, and the stated range covers the measured number.
By their numbers in this assay, from the lowest: compounds 4 and 3 (each within the scatter of the next); then compounds 2 and 1 (each within the scatter of the next).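

Shifting the chloro from 2-chlorophenyl to 3-chlorophenyl on the aromatic nitrogen gives a 1.1-fold lower number from compound 3 to compound 4 (0.04 log units; within the scatter) in this assay, so the two chlorophenyl compounds cannot be told apart there, and the tolerance to a shift around this ring, earlier seen only between the two methylphenyl compounds, now extends to chloro. Compound 4 also stands clear of both methylphenyl compounds, with a 3.4-fold lower number from compound 2 to compound 4 (0.53 log units; beyond the scatter) and a 5.5-fold lower number from compound 1 to compound 4 (0.74 log units; beyond the scatter) as its steps, so the separation earlier seen for compound 3 alone now holds for both chlorophenyl compounds, and none of the four compounds goes against it. Nothing in the data shown bears on what lies behind these numbers.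

The compounds shown leave open whether 4-chlorophenyl would fall with compound 3 and compound 4, and whether a phenyl ring carrying a methoxy group, an amine or a carboxylic acid would keep the number in this range. They also leave open whether the match between the two chlorophenyl compounds would hold in any other cell line or over a longer exposure.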